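The compounds below may be only part of what the source reports. "The series", "measured", "known", "first", "only" and "open" are said of these compounds alone.

Measured compounds:
`COc1cc(OC)c(OC)cc1/C=C/COC(=O)/C=C/c1ccccc1C(F)(F)F` (compound 1), 50% in a functional assay on the whole organism (strain Kunming) with Mus musculus as the target, with a stated time of 0.5 h, at a dose of 300 mg/kg by the intraperitoneal route; a higher number here means a weaker effect of the compound at the dose given, a lower number a stronger effect
`COc1cc(OC)c(OC)cc1/C=C/COC(=O)/C=C/c1ccc(F)cc1` (compound 2), 0%

Compound 2 stands lowest of the two numbers in this assay; its nearest neighbour is compound 1, which lies higher by a number 50 percentage points lower from compound 1 to compound 2 (beyond the scatter) in the reverse direction. Among the measured compounds shown here, that single step, in which 4-fluorophenyl replaces 2-(trifluoromethyl)phenyl on a double-bonded chain carbon bound to a double-bonded chain carbon, is the only measured step and is large and beyond the scatter. It shows that exchanging the aromatic group at this place can shift the activity a long way.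

Compound 3 is `COc1cccc(/C=C/C(=O)OC/C=C/c2cc(OC)c(OC)cc2OC)c1`. It differs from compound 2 by 3-methoxyphenyl in place of 4-fluorophenyl on a double-bonded chain carbon bound to a double-bonded chain carbon. For the measured compounds named here, no measured compound carries 3-methoxyphenyl, so the step from compound 1 to compound 2 bears on it only by analogy: a change of the aromatic group at this place has once moved the read-out strongly. Because compound 2 gives 0%, no further fall is possible; the expected step is therefore upward, of moderate size, a number 25 percentage points higher from compound 2 to compound 3 (beyond the scatter). The estimate for compound 3 in this assay is 25%, with a range from 0% to 60%.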

Compound 3, a percentage reported as activity, at one dose (the size of the read-out at that dose, not a potency): 50%
Compound 3: middle estimate off by 25 percentage points, on the low side; the range from low to high includes it.
By their numbers in this assay, from the lowest: compound 2; then compounds 1 and 3 (each within the scatter of the next).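

In this assay, 3-methoxyphenyl in place of 4-fluorophenyl on a double-bonded chain carbon bound to a double-bonded chain carbon brings a second large move (a number 50 percentage points higher from compound 2 to compound 3 (beyond the scatter)), so the large shift at this place is no longer tied to the 2-(trifluoromethyl)phenyl group alone. Exchanging 2-(trifluoromethyl)phenyl for 3-methoxyphenyl at the same place leaves the read-out unmoved (no change at the digits printed from compound 1 to compound 3 (within the scatter)), which shows that two differently substituted aromatic groups can read alike here, while 4-fluorophenyl alone stands apart among the three. Nothing available gives a reason for this separation.

The compounds shown leave open whether the standing of compound 2 belongs to fluorine specifically, as a chlorine or a plain phenyl ring at this place could tell, and whether a ring carrying an amine or a carboxylic acid would read with compound 2 or with the other two. They also leave open how far the pattern holds on any other core, since all three compounds share one core and one ester chain, and only the aromatic group varies.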